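The compounds below may be only part of what the source reports. "The series", "measured", "known", "first", "only" and "open" are said of these compounds alone.

Compound 1, `O=C1/C(=C/c2ccccc2Cl)CCc2cc(O)ccc21`: 1910 nM
Compound 2, `O=C1/C(=C/c2cccc(Cl)c2)CCc2cc(O)ccc21`: 1750 nM
Compound 3, `O=C1/C(=C/c2ccccc2Br)CCc2cc(O)ccc21`: 1070 nM

All three were tested in a functional assay on RAW264.7 cells (Mus musculus) for inhibition; a lower number here means a stronger inhibitor, a higher number a weaker inhibitor. Compound 1 and compound 3 share a core and differ by bromo in place of chloro on an aromatic carbon; that change gave a 1.8-fold lower number from compound 1 to compound 3 (0.25 log units; within the scatter). Compound 2 has the same atoms as compound 1, joined differently, and the difference between these two cores is not broken down here; in this assay compound 2 gives 1750 nM, and compound 1 gives 1910 nM, which are within the scatter of each other.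

Compound 4, `O=C1/C(=C/c2cccc(Br)c2)CCc2cc(O)ccc21`, has not yet been measured. It differs from compound 2 by bromo in place of chloro on an aromatic carbon. This is the same kind of change as from compound 1 to compound 3, but not the same: there the new group sat ortho to a large group, here it sits meta to a large group. The change appears in two pairs among the compounds shown, and only one pair is measured. For the measured compounds named here, the step is expected to be a 1.6-fold lower number from compound 2 to compound 4 (0.20 log units; within the scatter) in this assay, resting on the single measured example, a 1.8-fold lower number from compound 1 to compound 3 (0.25 log units; within the scatter). Compound 4 is therefore estimated at 1100 nM, between 500 nM and 2500 nM.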

Compound 4, half-maximal inhibitory concentration: 1140 nM
Compound 4: middle estimate off by 1.0-fold (0.02 log units), on the low side; the measured number falls inside the stated range.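

In this assay, putting bromo in place of chloro on the aromatic carbon meta to a large group gives a 1.5-fold lower number from compound 2 to compound 4 (0.19 log units; within the scatter), a step too small to count as a real difference on its own. Set beside the same swap on the other core, the two results agree: the same change on two cores in this assay, a 1.8-fold lower number (0.25 log units; within the scatter) from compound 1 to compound 3 and a 1.5-fold lower number (0.19 log units; within the scatter) from compound 2 to compound 4, 1.2-fold (0.07 log units) apart, within the scatter of two such steps

So in these two pairs, the swap behaves alike on both cores, and a step read on one core gave a fair guide to the other. This does not show that bromo truly differs from chloro here, since neither step stands clear of the scatter, and two pairs cannot establish a rule for other cores or other places on the ring.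

The compounds shown carry only these two halogens on this ring, so fluoro is an open question. So too is how an amine or a carboxylic acid would fare in the same place.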